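Three N-substituents on a shared cytotoxic core, and a fourth

The source may hold more compounds than are shown below. What is called first, only, known or untested is meant among the compounds shown, and "the series" means these compounds.

Compound 1 `C#CCn1c(-c2ccc(Cl)cc2)cc(-c2ccc(Cl)cc2)c(C#N)c1=O`: 16.7 ug/mL
Compound 2 `N#Cc1c(-c2ccc(Cl)cc2)cc(-c2ccc(Cl)cc2)n(CC2CO2)c1=O`: 5 ug/mL
Compound 3 `N#Cc1c(-c2ccc(Cl)cc2)cc(-c2ccc(Cl)cc2)n([C@@H]2O[C@H](CO)[C@@H](O)[C@H](O)[C@H]2O)c1=O`: 14.2 ug/mL

In a functional assay on MCF7 cells (Homo sapiens) for cytotoxicity, read by sulforhodamine B assay, with a stated time of 48 h (a lower number here means a stronger inhibitor, a higher number a weaker inhibitor), compound 3 gives the second highest of the three numbers shown. Its nearest neighbour is compound 1, and the step of a 1.2-fold lower number from compound 1 to compound 3 (0.07 log units; within the scatter) lies within the scatter, so the two cannot be ordered. Its furthest neighbour is compound 2, and the step of a 2.8-fold higher number from compound 2 to compound 3 (0.45 log units; beyond the scatter) is a modest one beyond the scatter, with compound 2 giving the lower number.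

Compound 4 `N#Cc1c(-c2ccc(Cl)cc2)cc(-c2ccc(Cl)cc2)n(CC(O)CCl)c1=O` differs from compound 3 at the aromatic nitrogen of the shared core: 3-chloro-2-hydroxypropyl in place of 3,4,5-trihydroxy-6-(hydroxymethyl)oxan-2-yl on an aromatic nitrogen

Both steps that end at compound 3 bear on this change, since each also replaces the group on the aromatic nitrogen. The move from propargyl to the trihydroxy-hydroxymethyl-oxanyl group, a 1.2-fold lower number from compound 1 to compound 3 (0.07 log units; within the scatter), changed nothing beyond the scatter, whereas the move from (oxiran-2-yl)methyl, a 2.8-fold higher number from compound 2 to compound 3 (0.45 log units; beyond the scatter), raised the number modestly. A short chain of five heavy atoms now enters in place of the ring, so a modest step toward a lower number in this assay is expected, of about the size of a 1.8-fold lower number from compound 3 to compound 4 (0.25 log units; within the scatter), though a result within the scatter of compound 3 would not be surprising. Compound 4 is therefore estimated at 8 ug/mL, within a range from 4 ug/mL to 17 ug/mL.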

Compound 4, half-maximal inhibitory concentration: 4.6 ug/mL
The estimate for compound 4 lay 1.7-fold (0.24 log units) above the measured number, within the range that was stated.
By their numbers in this assay, from the lowest: compounds 4 and 2 (each within the scatter of the next); then compounds 3 and 1 (each within the scatter of the next).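

In this assay, the 3-chloro-2-hydroxypropyl chain on the aromatic nitrogen gives a 3.1-fold lower number from compound 3 to compound 4 (0.49 log units; beyond the scatter), so the group at this position can move the number beyond the scatter when a chain replaces the 3,4,5-trihydroxy-6-(hydroxymethyl)oxan-2-yl ring. The step of a 1.1-fold lower number from compound 2 to compound 4 (0.04 log units; within the scatter) lies within the scatter, so the two groups cannot be ordered, and compound 4 shows that an oxiran-2-yl ring on this chain carbon is not needed to reach the number given by compound 2. With a 3.6-fold lower number from compound 1 to compound 4 (0.56 log units; beyond the scatter) also beyond the scatter, the four compounds fall into two groups, with compounds 2 and 4 giving lower numbers than compounds 1 and 3, which in turn cannot be ordered against each other.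

The compounds shown leave open whether the chlorine or the hydroxyl of the 3-chloro-2-hydroxypropyl chain carries the difference, and how a chain ending in an amine, a carboxylic acid or a plain longer alkyl group would compare at this nitrogen. Nothing available here accounts for why these groups sort as they do.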